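Halogen swaps on the benzyl ring of a triazole series

This account rests on a few compounds, and the source may have more. Where it says the series, first, only, none or still open, it means among the compounds named here.

Of the compounds shown here, three sharing one core have been tested in a functional assay on NCI/ADR-RES cells (Homo sapiens) for inhibition, read by sulforhodamine B assay, with a stated time of 48 h; on this read-out lower numbers stand for stronger inhibition of growth and higher numbers for weaker inhibition of growth. Compound 1 `Ic1ccc(Cn2cc(CCCOc3cccc4cccnc34)nn2)cc1` carries an iodo group on the benzyl ring; in this assay compound 1 reaches only the limit > 250 ug/mL, which is a limit and not a number. Compound 2 `Clc1ccc(Cn2cc(CCCOc3cccc4cccnc34)nn2)cc1` gives 11.6 ug/mL in this assay. Compound 3 `Brc1ccc(Cn2cc(CCCOc3cccc4cccnc34)nn2)cc1` gives 25.8 ug/mL in this assay, the higher of the two numbers obtained. The steps among them are an at least 21-fold lower number from compound 1 to compound 2 (1.33 log units; beyond the scatter), an at least 9.6-fold lower number from compound 1 to compound 3 (0.98 log units; beyond the scatter) and a 2.2-fold higher number from compound 2 to compound 3 (0.35 log units; beyond the scatter), so the smaller halogens sit at the lower numbers, with compound 1 at the top as a limit (the limit of > 250 ug/mL in this assay, at which 1 of the 3 values shown sits).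

Compound 4 `Fc1ccc(Cn2cc(CCCOc3cccc4cccnc34)nn2)cc1F` has not been measured. It differs from compound 3 in that (3,4-difluorophenyl in place of 4-bromophenyl on a saturated chain carbon bound to an aromatic nitrogen). Of the measured steps, a 2.2-fold higher number from compound 2 to compound 3 (0.35 log units; beyond the scatter) and an at least 9.6-fold lower number from compound 1 to compound 3 (0.98 log units; beyond the scatter) bear most directly, since both exchange the halogen on that ring, and both point toward a lower number as the halogen shrinks. Within the data shown here, compound 4 is therefore expected to give a modest step downward in this assay, about a 2.6-fold lower number from compound 3 to compound 4 (0.41 log units; beyond the scatter), although a second fluoro has no precedent here. The estimate for compound 4 is 10 ug/mL, within a range from 3 ug/mL to 40 ug/mL.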

Compound 4, concentration for 50% growth inhibition: 42.1 ug/mL
For compound 4 the middle estimate is 4.2-fold (0.62 log units) below the measured one; measured number above the stated range.
By their numbers in this assay, from the lowest: compound 2; then compounds 3 and 4 (each within the scatter of the next). At a limit, above all of these: compound 1.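

In this assay, the 4-bromophenyl group gives way to 3,4-difluorophenyl, and the result is a 1.6-fold higher number from compound 3 to compound 4 (0.21 log units; within the scatter), so at this position the exchange of one group for the other produces no difference that stands clear of the scatter. Set against 4-chlorophenyl, the same group gives a 3.6-fold higher number from compound 2 to compound 4 (0.56 log units; beyond the scatter), so compound 4 goes against the earlier trend of lower numbers with smaller halogens, and compound 2 keeps the lowest number of the series. Against 4-iodophenyl the step is an at least 5.9-fold lower number from compound 1 to compound 4 (0.77 log units; beyond the scatter), which rests on a limit and not on a number: the limit of > 250 ug/mL in this assay, at which 1 of the 4 values shown sits.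

The compounds shown leave open how 4-fluorophenyl alone would compare with 4-chlorophenyl and 3,4-difluorophenyl, and whether a methoxy group, a nitrile or an amine on the benzyl ring would fall within the same range. They also leave open how a shorter or longer chain in the shared core would change the numbers for the 4-chlorophenyl compound.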